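The source may hold more compounds than are shown below. What is called first, only, known or untested is meant among the compounds shown, and "the series" means these compounds.

Measured in a functional assay on HL-60 cells (Homo sapiens) for cytotoxicity, read by MTT assay, with a stated time of 48 h; a higher number here means a weaker inhibitor, a lower number a stronger inhibitor:
compound 1, `COc1ccc(-c2c[nH]c(=O)n2-c2cc(OC)c(OC)c(OC)c2)cc1[N+](=O)[O-]`, 14300 nM
compound 2, `COc1ccc(-c2c[nH]c(=O)n2-c2cc(OC)c(OC)c(OC)c2)cc1N`, 10300 nM
compound 3, `COc1ccc(-c2cn(C(C)=O)c(=O)n2-c2cc(OC)c(OC)c(OC)c2)cc1[N+](=O)[O-]`, 5600 nM

Compound 2 arises from compound 1 by one change, (amino in place of nitro on an aromatic carbon). That step is a 1.4-fold lower number from compound 1 to compound 2 (0.14 log units; within the scatter). Compound 3 arises from compound 1 by a different change, which also separates the two cores compared here, (acetyl in place of hydrogen on an aromatic nitrogen), and that step is a 2.6-fold lower number from compound 1 to compound 3 (0.41 log units; beyond the scatter).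

Compound 4, `COc1ccc(-c2cn(C(C)=O)c(=O)n2-c2cc(OC)c(OC)c(OC)c2)cc1N`, has not been measured. It stands to compound 3 as compound 2 stands to compound 1, by the change (amino in place of nitro on an aromatic carbon). The surroundings of the changed position are described in the same words in both cases, so this is the same change, made on the core that carries the acetyl group. For the measured compounds named here, only one earlier instance of it is known, and it stayed within the scatter. For compound 4 the step is expected to be about as small, a 1.3-fold lower number from compound 3 to compound 4 (0.12 log units; within the scatter), because the earlier instance moved a 1.4-fold lower number from compound 1 to compound 2 (0.14 log units; within the scatter). On that basis compound 4 is estimated at 4200 nM, likely between 1800 nM and 10000 nM.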

Compound 4, half-maximal inhibitory concentration: 400 nM
For compound 4 the middle estimate is 11-fold (1.02 log units) above the measured one; the measured number lies below the stated range.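

In this assay, amino in place of nitro gives a 14-fold lower number from compound 3 to compound 4 (1.15 log units; beyond the scatter) on the core that carries the acetyl group, so the size of this step does not carry over from the core without that group: the same change on two cores in this assay, a 1.4-fold lower number (0.14 log units; within the scatter) from compound 1 to compound 2 and a 14-fold lower number (1.15 log units; beyond the scatter) from compound 3 to compound 4, 10-fold (1.00 log units) apart, beyond the scatter of two such steps

Read the other way, acetyl in place of hydrogen on the aromatic nitrogen gives a 26-fold lower number from compound 2 to compound 4 (1.41 log units; beyond the scatter), so the size of that step depends on whether the ring carries amino or nitro: the same change on two cores in this assay, a 2.6-fold lower number (0.41 log units; beyond the scatter) from compound 1 to compound 3 and a 26-fold lower number (1.41 log units; beyond the scatter) from compound 2 to compound 4, 10-fold (1.00 log units) apart, beyond the scatter of two such steps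

Both comparisons rest on the same four compounds, so they are one observation seen from two sides: amino and acetyl together do more than their separate steps would suggest, but this does not show why, or whether it would hold on any other core.

The compounds shown leave open whether a longer acyl chain such as propanoyl, or a plain methyl, on that nitrogen would act as acetyl does here. They also leave open whether a dimethylamino or hydroxyl group in place of amino would keep the large step.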